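Swapping Bromine for Chlorine on a Cytotoxic Isatin Scaffold

The source may hold more compounds than are shown below. What is called first, only, known or untested is meant among the compounds shown, and "the series" means these compounds.

Measured compounds:
compound 1, `CCN(CC)CN1C(=O)/C(=N\c2nc3ccc(C)cc3s2)c2c(Br)cccc21`: 28700 nM
compound 2, `CCN(CC)CN1C(=O)C(=O)c2c(Br)cccc21`: 20200 nM
compound 3, `CCN(CC)CN1C(=O)C(=O)c2c(Cl)cccc21`: 44500 nM

Of the compounds shown here, three have been tested in a functional assay on MDA-MB-231 cells (Homo sapiens) for cytotoxicity, read by sulforhodamine B assay, with a stated time of 48 h; a lower number here means a stronger inhibitor of growth, a higher number a weaker inhibitor of growth. Compound 2, `CCN(CC)CN1C(=O)C(=O)c2c(Br)cccc21`, gives 20200 nM in this assay, and compound 3, `CCN(CC)CN1C(=O)C(=O)c2c(Cl)cccc21`, gives 44500 nM. These two differ in one place only: chloro in place of bromo on an aromatic carbon. That change produced a 2.2-fold higher number from compound 2 to compound 3 (0.34 log units; beyond the scatter).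

Compound 1, `CCN(CC)CN1C(=O)/C(=N\c2nc3ccc(C)cc3s2)c2c(Br)cccc21`, carries a larger appendage on the shared core; the difference between its core and that of compound 2 is not broken down here. In this assay compound 1 gives 28700 nM, and the gap to compound 2 lies within the scatter of the method, so no order between them can be claimed.

Compound 4, `CCN(CC)CN1C(=O)/C(=N\c2nc3ccc(C)cc3s2)c2c(Cl)cccc21`, has not yet been measured. It is related to compound 1 exactly as compound 3 is to compound 2: chloro in place of bromo on an aromatic carbon. The place lines for both pairs read the same, so this is the same change made on a second pair. Applying the step seen from compound 2 to compound 3 to the value of compound 1, compound 4 is expected to show a 1.7-fold higher number from compound 1 to compound 4 (0.24 log units; within the scatter), resting on the single earlier example a 2.2-fold higher number from compound 2 to compound 3 (0.34 log units; beyond the scatter). For the measured compounds named here, with only one precedent, the expectation is loose, and compound 4 is estimated at 50000 nM, between 25000 nM and 100000 nM.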

Compound 4, concentration for 50% growth inhibition: 20400 nM
Beside the measured number, compound 4's estimate is 2.5-fold (0.39 log units) above it; the measured number lies below the stated range.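

In this assay, putting chloro in place of bromo on an aromatic carbon of the larger compound gives a 1.4-fold lower number from compound 1 to compound 4 (0.15 log units; within the scatter), so this pair cannot be told apart by the measurement, even though the same swap on the smaller core gave a step beyond the scatter. The result of this swap therefore did not carry over from one core to the other in this series, and the size of the step seen on one core was a poor guide to the step on the other: the same change on two cores in this assay, a 2.2-fold higher number (0.34 log units; beyond the scatter) from compound 2 to compound 3 and a 1.4-fold lower number (0.15 log units; within the scatter) from compound 1 to compound 4, 3.1-fold (0.49 log units) apart, beyond the scatter of two such steps. For the compounds shown here, this shows that the outcome of the swap depends on the core it is made on, but with only one pair per core it does not show which part of the larger core is responsible, or why the two steps differ.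

The compounds shown leave open how other groups at this aromatic carbon, such as fluoro, a methoxy group or an amine, would behave on either core. They also leave open whether a third core would follow the pattern of compound 2 and compound 3 or that of compound 1 and compound 4.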